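The compounds below may be only part of what the source reports. "The series", "measured", "known", "first", "only" and "open" are said of these compounds alone.

Of the compounds shown here, three have been measured in a functional assay on HeLa cells (Homo sapiens) for cytotoxicity, read by MTT assay, with a stated time of 72 h; on this read-out higher numbers stand for weaker inhibition and lower numbers for stronger inhibition. Compound 1 `CC(=O)N(/N=N/c1ccc(Cl)c(C(F)(F)F)c1)c1ccc(Cl)c(C(F)(F)F)c1` gives 50600 nM, and compound 2 `CC(=O)Oc1ccc(/C=C/C(=O)N(/N=N/c2ccc(Cl)c(C(F)(F)F)c2)c2ccc(Cl)c(C(F)(F)F)c2)cc1OC(C)=O` gives 43000 nM. Compound 3 `O=[N+]([O-])c1ccc(/N=N/Nc2ccc([N+](=O)[O-])cc2Br)c(Br)c1` gives 940 nM, the lowest of the three numbers; the nearest, compound 2, stands well higher, and compound 1 higher still, both gaps beyond the scatter, so compound 3 is the strongest of the three in this assay.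

Compound 4 `CC(=O)N(/N=N/c1ccc([N+](=O)[O-])cc1Br)c1ccc([N+](=O)[O-])cc1Br` has not been measured. It differs from compound 3 in one place: acetyl in place of hydrogen on a nitrogen on an aromatic ring. Among the measured compounds shown here, no measured pair shows this exact change on an otherwise equal scaffold, so its effect cannot be read off directly. Compound 1, which carries an acetyl on the corresponding nitrogen, is among the weak compounds, but it also differs from compound 3 in the ring substituents, so the two changes cannot be separated. The expected step from compound 3 to compound 4 is therefore toward a weaker result, by a 9.6-fold higher number from compound 3 to compound 4 (0.98 log units; beyond the scatter), with wide uncertainty. Compound 4 is estimated at 9000 nM, within a range of 2500 nM to 35000 nM.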

Compound 4, half-maximal inhibitory concentration: 550 nM
Beside the measured number, compound 4's estimate is 16-fold (1.21 log units) above it, and the stated range ends above it.
By their numbers in this assay, from the lowest: compounds 4 and 3 (each within the scatter of the next); then compounds 2 and 1 (each within the scatter of the next).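

In this assay, among the compounds shown here, the pair of compound 3 and compound 4 is the first to isolate acetyl in place of hydrogen on a nitrogen on an aromatic ring, and it gives a 1.7-fold lower number from compound 3 to compound 4 (0.23 log units; within the scatter). On the core these two compounds share, the hydrogen on this nitrogen is therefore not needed to keep the number in this range, and the acetyl can stand there without a change beyond the scatter. Nothing measured here explains why the number holds when the acetyl enters.

On these data alone, it remains open whether this nitrogen on the same core would accept a different group, such as a methyl or a benzoyl. As far as these compounds go, it is also open whether hydrogen in place of acetyl on the core of compound 1 would give a similarly small step.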